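Tert-butyl for amino on the sulfonamide aryl of compound 1

A few compounds are considered here, and "the series" means these few. Any claim that something is new, unique, unknown or untested is made for them only; others in the source may bear on it.

Compound 1 `Cc1onc(NS(=O)(=O)c2ccc(N)cc2)c1I` is examined in an assay on COS-7 cells for displacement of a labelled ligand from Endothelin receptor type B (Sus scrofa); a higher number here means a weaker inhibitor, a lower number a stronger inhibitor. In this assay compound 1 gives > 1000000 nM, which is a limit of the assay and not a number. Two further compounds are known: compound 2 `COc1cccc(Sc2c(NS(=O)(=O)c3ccc(C(C)(C)C)cc3)noc2CCCC#N)c1` gives 520 nM in this assay, and compound 3 `COc1cccc(Sc2c(NS(=O)(=O)c3ccc(C(C)(C)C)cc3)noc2CCCC(=O)O)c1` gives 500 nM. Among the compounds with values here, the only measured step, a 1.0-fold lower number from compound 2 to compound 3 (0.02 log units; within the scatter), concerns a change on the chain and leaves the sulfonamide aryl untouched. Compound 4 `Cc1onc(NS(=O)(=O)c2ccc(C(C)(C)C)cc2)c1I` is not yet measured; it differs from compound 1 by tert-butyl in place of amino on an aromatic carbon. Within the data shown here, no measured step covers this change directly: the only pair sharing nothing but the tert-butyl, compounds 2 and 3, differs from compound 1 in several further places, so their values cannot be set against it. Compound 1 stands at the limit of > 1000000 nM in this assay, at which 1 of the 3 values shown sits, so the size of the step is open. For compound 4 an estimate of 200000 nM is made, with a range from 5000 nM to 2000000 nM, meaning an expected step of an at least 5.0-fold lower number from compound 1 to compound 4 (0.69 log units; beyond the scatter).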

Compound 4, half-maximal inhibitory concentration: 30000 nM
Beside the measured number, compound 4's estimate is 6.7-fold (0.82 log units) above it; measured number inside the range.
By their numbers in this assay, from the lowest: compounds 3 and 2 (each within the scatter of the next); then compound 4. At a limit, above all of these: compound 1.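

Within the data shown here, the step of an at least 33-fold lower number from compound 1 to compound 4 (1.52 log units; beyond the scatter), read in this assay, is the first measured effect of a change on the sulfonamide aryl, since the earlier step concerned only the chain. It shows that tert-butyl in place of amino on this aromatic carbon, para to a large group, is enough to move the core of compound 1 beyond the scatter. Compound 1 stands at a limit of the assay and not a number, so the step gives only a minimum size: the limit of > 1000000 nM in this assay, at which 1 of the 4 values shown sits.

The compounds shown leave open how other groups at this position, such as a methyl, a methoxy or a carboxylic acid, would compare with tert-butyl and amino. They also leave open whether the change has a similar size on the core of compound 2, where an amine in place of tert-butyl has no value here.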